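Ring size at the amide carbonyl: notes toward compound 3

This account rests on a few compounds, and the source may have more. Where it says the series, first, only, none or still open, it means among the compounds named here.

Measured so far:
compound 1 `CCOC(=O)N1CCC(N2CCC[C@@H](NC(=O)C3CCCC3)C2)CC1` — > 10000 nM
compound 2 `CCOC(=O)N1CCC(N2CCC[C@@H](NC(=O)c3cccc(F)c3)C2)CC1` — > 10000 nM

In a functional assay on CHO cells for agonist activity at muscarinic acetylcholine receptor M5 (Rattus norvegicus) (on this read-out higher numbers stand for an effect only at larger amounts of compound and lower numbers for an effect already at smaller amounts), compound 1 gives no number, only a limit, > 10000 nM. Compound 2 likewise returns only a limit in this assay, > 10000 nM. Among the measured compounds shown here, the single measured step, a step that the two limits leave unreadable from compound 1 to compound 2, is unreadable because the limit of > 10000 nM in this assay, at which 2 of the 2 values shown sit, holds both ends of it, so neither direction nor size can be taken from it.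

Compound 3 `CCOC(=O)N1CCC(N2CCC[C@@H](NC(=O)C3CCCCC3)C2)CC1` differs from compound 1 by cyclohexyl in place of cyclopentyl on a carbonyl carbon. For the measured compounds named here, no measured step speaks to this kind of change; the one step on record swaps a 3-fluorophenyl for the cyclopentyl and is itself unreadable. With compound 1 standing at the limit, compound 3 is expected to remain there or close to it, and a step that the limit leaves unreadable from compound 1 to compound 3 is expected to be no step beyond the scatter. For compound 3 the estimate in this assay is 15000 nM, within 5000 nM to 50000 nM, most probably reported again only as a limit.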

Compound 3, half-maximal effective concentration: > 10000 nM
Compound 3: only a limit was reported (the forecaster's own chance of this, stated with the estimate: 85%); the middle value is on the limit's open side.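

Compound 3 joins compound 1 and compound 2 as a limit and not a number, so no step among the three can be read in this assay: the limit of > 10000 nM in this assay, at which 3 of the 3 values shown sit.

The compounds shown leave open how cyclopentyl, cyclohexyl and 3-fluorophenyl on the carbonyl carbon rank in this assay and whether any of them gives a measurable effect.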